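The source may report more compounds than this note shows. Statements on the series, on what has been measured and on what is new or still open speak of the compounds shown alone.

Measured in a functional assay on HeLa cells (Homo sapiens) for inhibition, read by MTT assay, with a stated time of 72 h; on this read-out higher numbers stand for weaker inhibition and lower numbers for stronger inhibition:
compound 1 `CCCCCCCCCCCCc1ccc(C(=O)/C=C/C(=O)O)cc1` gives 5820 nM
compound 2 `CCc1ccc(C(=O)/C=C/C(=O)O)cc1` gives 27800 nM
compound 3 `CCc1c(C(=O)/C=C/C(=O)O)cc(C(C)C)cc1C(C)C` gives 7610 nM

Compound 2 stands highest of the three numbers in this assay, so it is the weakest inhibitor shown; compound 3 comes nearest, lower by a margin beyond the usual scatter, and compound 1 lies furthest, also beyond the scatter. Compound 4 `O=C(O)/C=C/C(=O)c1ccc(Cl)cc1` has not yet been measured. It differs from compound 2 in one place: chloro in place of ethyl on an aromatic carbon. Within the data shown here, no pair of measured compounds differs by this kind of swap alone, so nothing here shows what it does to inhibition. With one small group giving way to another, the expected step in this assay is none beyond the scatter, in either direction. Compound 4 is therefore estimated at 25000 nM, with a range from 8000 nM to 70000 nM. The expected step is a 1.1-fold lower number from compound 2 to compound 4 (0.05 log units; within the scatter).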

Compound 4, half-maximal inhibitory concentration: 25400 nM
Beside the measured number, compound 4's estimate is 1.0-fold (0.01 log units) below it; measured number inside the range.
By their numbers in this assay, from the lowest: compounds 1 and 3 (each within the scatter of the next); then compounds 4 and 2 (each within the scatter of the next).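

In this assay, placing chloro instead of ethyl on the aromatic carbon para to a group of 7 heavy atoms gives a 1.1-fold lower number from compound 2 to compound 4 (0.04 log units; within the scatter) and so lies within the scatter. Among these compounds, this is the first measured pair to test a single swap at this position, and it shows that chloro and ethyl cannot be told apart here. Nothing measured here gives a reason for this match. Still open, going by these compounds, is whether an amine, a methoxy group or a nitrile at this position would also fall within the scatter of compound 4.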